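Cyano and trifluoromethyl on the anilide of a rhodanine

The source may report more compounds than this note shows. Statements on the series, on what has been measured and on what is new or still open speak of the compounds shown alone.

Compound 2 `O=C(CN1C(=O)/C(=C/c2ccc(-c3ccc(Cl)cc3)o2)SC1=S)NCc1ccc(F)cc1` has the highest of two numbers in a functional assay on REH cells (Homo sapiens) for cytotoxicity, read by MTT assay, with a stated time of 72 h (a lower number here means a stronger inhibitor, a higher number a weaker inhibitor), giving 165000 nM; compound 1 `N#Cc1ccc(NC(=O)CN2C(=O)/C(=C/c3ccc(-c4ccc(Cl)cc4)o3)SC2=S)cc1` gives 90000 nM, and the step of a 1.8-fold higher number from compound 1 to compound 2 (0.26 log units; within the scatter) lies within the scatter. Compound 3 `N#Cc1cc(NC(=O)CN2C(=O)/C(=C/c3ccc(-c4ccc(Cl)cc4)o3)SC2=S)ccc1C(F)(F)F` differs from compound 2 by 3-cyano-4-(trifluoromethyl)phenyl in place of 4-fluorobenzyl on an amide-type nitrogen. Among the compounds with values here, only that one measured step bears on this change, and it moved the number little when 4-cyanophenyl was exchanged for 4-fluorobenzyl. Restoring a phenyl ring that carries a nitrile is therefore expected to give a step of a 1.9-fold lower number from compound 2 to compound 3 (0.29 log units; within the scatter) that stays within the scatter. Compound 3 is expected at 85000 nM, within 25000 nM to 300000 nM.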

Compound 3, half-maximal inhibitory concentration: > 250000 nM
Compound 3: only a limit was reported (the forecaster's own chance of this, stated with the estimate: 20%); middle value at least 2.9-fold (0.46 log units) from the limit.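

For compound 3 the reading in this assay is a limit, not a number: the limit of > 250000 nM in this assay, at which 1 of the 3 values shown sits.

Placing 3-cyano-4-(trifluoromethyl)phenyl on the amide-type nitrogen in place of 4-cyanophenyl gives an at least 2.7-fold higher number from compound 1 to compound 3 (0.44 log units; beyond the scatter), so this position does respond to a change on the phenyl ring that keeps a nitrile. Against 4-fluorobenzyl the same group gives an at least 1.5-fold higher number from compound 2 to compound 3 (0.18 log units; that floor lies within the scatter), and that floor alone does not separate the two.

On these data alone, the true number of compound 3 stays open. So does the effect of an amine or a carboxylic acid in place of this aromatic group.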